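Methoxy added to the phenyl ring of compound 1

This account rests on a few compounds, and the source may have more. Where it says the series, first, only, none or still open, it means among the compounds named here.

Measured so far in an ADME assay on HEL cells (Homo sapiens) for cytotoxicity, with a stated time of 3 days; on this read-out lower numbers stand for higher toxicity in this test and higher numbers for lower toxicity in this test:
compound 1 `Cc1cc(-c2ccccc2)c2ncc(CSCCc3ccccc3)n2c1` gives 20 ug/mL;
compound 2 `Cc1cc(-c2ccc(O)cc2)cn2c(CSCCc3ccccc3)cnc12` gives >= 100 ug/mL, which is a limit of the test and not a number;
compound 3 `Cc1cc(-c2ccsc2)cn2c(CSCCc3ccccc3)cnc12` gives >= 4 ug/mL, also a limit of the test.

Going by the values given here, compound 1 holds the only actual number among the three values; the other two sit at limits (the limit of >= 100 ug/mL in this assay, at which 1 of the 3 values shown sits, and (the limit of >= 4 ug/mL in this assay, at which 1 of the 3 values shown sits)). Among the compounds with values here, the one measured step, a step that the two limits leave unreadable from compound 2 to compound 3, cannot be read for size because both ends are limits.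

Compound 4 `COc1cccc(-c2cc(C)cn3c(CSCCc4ccccc4)cnc23)c1` differs from compound 1 by methoxy in place of hydrogen on an aromatic carbon. Within the data shown here, no measured step matches this change, and the single readable step gives no size to compare. Compound 4 is therefore expected to stay near compound 1, with a step of no change at the digits printed from compound 1 to compound 4 (within the scatter) that need not exceed the usual scatter. The estimate for compound 4 is 20 ug/mL, ranging from 7 ug/mL to 60 ug/mL.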

Compound 4, minimum cytotoxic concentration: 100 ug/mL
Compound 4: middle estimate off by 5.0-fold (0.70 log units), on the low side; the measured number lies above the stated range.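

In this assay, one methoxy on the phenyl ring, meta to a large group, brings a 5.0-fold higher number from compound 1 to compound 4 (0.70 log units; beyond the scatter) and so lower toxicity in this test. Going by these compounds alone, this is the first size that can be read for any change to an aromatic ring, since the earlier step between two limits cannot be read. Nothing shown here accounts for the rise.

From the compounds shown here alone, whether an amine or a carboxylic acid in this same place would move the number as methoxy does remains open. So does whether a longer chain such as ethoxy would.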